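The source may report more compounds than this note shows. Statements on the series, on what has been measured and on what is new or still open speak of the compounds shown alone.

In a functional assay on HepG2 cells (Homo sapiens) for antiproliferative activity, read by MTT assay, with a stated time of 48 h (on this read-out higher numbers stand for weaker inhibition and lower numbers for stronger inhibition), two compounds built on the same core have been measured so far. Compound 1 `CC(=O)N1N=C(c2ccc3ccccc3c2)OC1c1ccccc1[N+](=O)[O-]` gives 12.3 ug/mL. Compound 2 `CC(=O)N1N=C(c2ccc3ccccc3c2)OC1c1ccccc1O`, with hydroxy in place of nitro on an aromatic carbon, gives 1.84 ug/mL, the lower of the two numbers and so the stronger inhibition. That change is a 6.7-fold lower number from compound 1 to compound 2 (0.83 log units; beyond the scatter), which lies beyond the scatter of repeated measurements.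

Compound 3 `CC(=O)N1N=C(c2ccc3ccccc3c2)OC1c1cccnc1` replaces the whole ring rather than one group on it, with pyridin-3-yl in place of 2-hydroxyphenyl on a saturated ring carbon. Among the measured compounds shown here, only one measured step bears on this change, and no measured compound carries pyridin-3-yl, so the guidance is thin. That step does show that a change on this aromatic substituent can move the number clearly. Compound 1, which also has no hydroxy, stands at 12.3 ug/mL. A move of similar or smaller size toward weaker inhibition therefore seems likely. The expected change is a 3.3-fold higher number from compound 2 to compound 3 (0.51 log units; beyond the scatter). Compound 3 is estimated at 6 ug/mL, with an expected range from 1.5 ug/mL to 22 ug/mL.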

Compound 3, half-maximal inhibitory concentration: 2.86 ug/mL
Compound 3: the middle estimate sits 2.1-fold (0.32 log units) above what was measured; the measured number falls inside the stated range.
By their numbers in this assay, from the lowest: compounds 2 and 3 (each within the scatter of the next); then compound 1.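

In this assay, exchanging the whole 2-hydroxyphenyl ring for pyridin-3-yl on the saturated ring carbon leaves compound 2 and compound 3 indistinguishable (a 1.6-fold higher number from compound 2 to compound 3 (0.19 log units; within the scatter)), even though the group that enters has no hydrogen-bond donor and carries a ring nitrogen. The first pair alone could be read as a gain tied to the hydroxy group, but compound 3 has no hydroxy group and still stands clearly apart from the nitro compound (a 4.3-fold lower number from compound 1 to compound 3 (0.63 log units; beyond the scatter)), so within these three compounds a hydroxy group is not needed for the lower number, and only the 2-nitrophenyl compound stands apart. Nothing available here explains why these two different rings give numbers within the scatter of each other, or why the 2-nitrophenyl compound stands apart.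

Still open, from the compounds shown here alone, is whether that lower number holds with a plain phenyl, 2-methoxyphenyl, 2-aminophenyl or pyridin-4-yl group on the same carbon. The compounds shown also leave open what happens when the acetyl group gives way to a longer chain such as butanoyl.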